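Nitrophenyl for Chlorofluorophenyl in a Glioblastoma Cell Assay

A few compounds are considered here, and "the series" means these few. Any claim that something is new, unique, unknown or untested is made for them only; others in the source may bear on it.

Measured so far:
compound 1 `Oc1cc2c(cc1C(c1ccc(F)cc1)N1CCCCC1)OCCO2` — 1000 nM
compound 2 `Cc1ccnc(NC(c2ccc3cccnc3c2O)c2c(F)cccc2Cl)c1` — 20600 nM

Both compounds were tested in a functional assay on U-87MG ATCC cells for inhibition, with U-87 MG (Homo sapiens) as the target, read by MTT assay, with a stated time of 72 h; a lower number here means a stronger inhibitor, a higher number a weaker inhibitor. Compound 1 gives 1000 nM. Compound 2 gives 20600 nM, the highest of the two numbers recorded; the gap to compound 1 is beyond the scatter. The two compounds share no single point of difference, so the numbers only show that compound 2 is the weaker of the pair.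

Compound 3 `Cc1ccnc(NC(c2ccc([N+](=O)[O-])cc2)c2ccc3cccnc3c2O)c1` is not yet measured. It differs from compound 2 at one place: 4-nitrophenyl in place of 2-chloro-6-fluorophenyl on a saturated chain carbon bound to an aromatic carbon and a nitrogen on an aromatic ring

Going by the values given here, no measured pair shows a step of this kind, so there is no basis for expecting a shift in this assay beyond the scatter in either direction. Compound 3 is therefore expected to land near compound 2, with the step from compound 2 to compound 3 estimated as a 1.0-fold lower number from compound 2 to compound 3 (0.01 log units; within the scatter). For compound 3 the estimate is 20000 nM, within a range from 5000 nM to 70000 nM.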

Compound 3, half-maximal inhibitory concentration: 3400 nM
The estimate for compound 3 lay 5.9-fold (0.77 log units) above the measured number, outside the stated range (below it).
By their numbers in this assay, from the lowest: compound 1; then compound 3; then compound 2.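

In this assay, the saturated chain carbon bound to an aromatic carbon and a nitrogen on an aromatic ring proves sensitive to the aryl group it carries: 4-nitrophenyl in place of 2-chloro-6-fluorophenyl gives a 6.1-fold lower number from compound 2 to compound 3 (0.78 log units; beyond the scatter). This is the first change in one place among these compounds, and it shows that the number responds to this exchange by more than the usual scatter while the rest of the structure stays the same. No evidence is available to explain the shift.

The compounds shown leave open whether the step follows from gaining the nitro group or from losing the chlorine and fluorine. A plain phenyl group on the same carbon would help to separate the two, and a 4-aminophenyl group would test whether the nitro group can be replaced.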